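Swapping Fluoro for Methyl on a Mitochondrial Activator

The source may report more compounds than this note shows. Statements on the series, on what has been measured and on what is new or still open speak of the compounds shown alone.

Among the compounds with values here, compound 3 `Fc1ccc(Nc2nc3nonc3nc2Nc2ccccc2F)cc1` is the only one of three compounds to give a number rather than a limit in an assay on mitochondria from L6 cells (Rattus norvegicus) for activation, with a stated time of 90 min; a higher number here means that more compound is needed for the effect, a lower number that less compound is needed; compound 3 gives 2300 nM. For compound 1 `FC(F)(F)Oc1ccc(Nc2nc3nonc3nc2Nc2ccc(OC(F)(F)F)cc2)cc1` only a limit is reported, < 5000 nM (the limit of < 5000 nM in this assay, at which 1 of the 3 values shown sits). For compound 2 `Fc1ccccc1Nc1nc2nonc2nc1NCCC(F)(F)F` the result is likewise a limit, > 100000 nM (the limit of > 100000 nM in this assay, at which 1 of the 3 values shown sits). Within the data shown here, the single measured step, an at least 43-fold lower number from compound 2 to compound 3 (1.63 log units; beyond the scatter), concerns a different kind of change and does not bear on the move to compound 4 `Cc1ccc(Nc2nc3nonc3nc2Nc2ccccc2F)cc1`, which differs from compound 3 by methyl in place of fluoro on an aromatic carbon. Among the measured compounds shown here, with no measured step to guide the direction, no change beyond the scatter is expected. Compound 4 is therefore estimated at 2500 nM, between 800 nM and 8000 nM. The expected step is a 1.1-fold higher number from compound 3 to compound 4 (0.04 log units; within the scatter).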

Compound 4, half-maximal effective concentration: 2100 nM
The estimate for compound 4 lay 1.2-fold (0.08 log units) above the measured number; the range from low to high includes it.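

In this assay the swap gives a 1.1-fold lower number from compound 3 to compound 4 (0.04 log units; within the scatter) and so shows that, on this aromatic carbon, methyl and fluoro cannot be told apart. The 4-methylphenyl group gives an at least 47-fold lower number from compound 2 to compound 4 (1.67 log units; beyond the scatter) and so repeats the large step already seen with 4-fluorophenyl. That step rests on compound 2, which has a limit and not a number: the limit of > 100000 nM in this assay, at which 1 of the 4 values shown sits.

From the compounds shown here alone, whether an amine, a carboxylic acid or a longer chain on this carbon would also stay within the scatter of compound 3 remains open. So does the result of leaving this carbon with only hydrogen.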